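Removing the bromo from compound 2: what to expect

The compounds below may be only part of what the source reports. "The series", "measured", "known", "first", "only" and "open" are said of these compounds alone.

Of the compounds shown here, two that share one core have been tested in a functional assay on the whole organism for inhibition, with Rattus norvegicus as the target, at a dose of 30 mg/kg; a lower number here means less inhibition, a higher number more inhibition at the dose given (going by the name of the read-out). Compound 1, `Fc1ccc(F)c(-c2nc3ncccc3o2)c1`, gives 18%. Compound 2, `Brc1cccc(-c2nc3ncccc3o2)c1`, gives 23%. Among the two numbers, compound 2 stands at the higher one, yet its only neighbour, compound 1, sits within the scatter of it, so the two cannot be told apart on these data.

Compound 3, `c1ccc(-c2nc3ncccc3o2)cc1`, is still unmeasured. It differs from compound 2 in one place: hydrogen in place of bromo on an aromatic carbon.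

Going by the values given here, no measured pair shows how this change acts on this core, so the expectation rests only on the narrow spread between compound 1 and compound 2. The step expected from compound 2 to compound 3 is a number 8 percentage points lower from compound 2 to compound 3 (within the scatter), small and downward, not beyond the scatter. For compound 3 the estimate is 15%, with a range from 0% to 30%.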

Compound 3, a percentage reported as inhibition, in the whole organism at one dose (the size of the read-out at that dose, not a potency): 41%
Beside the measured number, compound 3's estimate is 26 percentage points below it; measured number outside the range, above it.
By their numbers in this assay, from the lowest: compounds 1 and 2 (each within the scatter of the next); then compound 3.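

In this assay, the bromo on this aromatic carbon proves not to be needed for the effect: putting hydrogen in its place gives a number 18 percentage points higher from compound 2 to compound 3 (beyond the scatter) at the same dose. Going by these compounds alone, this is the first measured single change on the shared core, and it shows that the read-out does respond to what sits at this position, with the ring that carries no bromo giving the larger inhibition. Nothing measured here explains the direction of this step.

On these data alone, whether another group on the same aromatic carbon, such as an amine, a methoxy or a carboxylic acid, would raise the inhibition further or lower it stays open. As far as these compounds go, with one pair and one dose, it is also open whether this swap would act the same way on other compounds or at other doses.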